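A few compounds are considered here, and "the series" means these few. Any claim that something is new, unique, unknown or untested is made for them only; others in the source may bear on it.

Working notes on the series built on the core of compound 1 `C=CCc1cc(OC)c(OC(C)C(OCCCCCCCC)c2ccc(O)c(OC)c2)c(OC)c1`, where the alkyl ether at the saturated chain carbon is varied. In an assay on HEK293 cells for agonist activity at transient receptor potential cation channel subfamily M member 8 (Homo sapiens), read by fluorescence and calcium flux, with a stated time of 5 min (on this read-out higher numbers stand for an effect only at larger amounts of compound and lower numbers for an effect already at smaller amounts), compound 1 gives 86 nM, the lowest number among the three measured compounds. Compound 2 `C=CCc1cc(OC)c(O[C@H](C)[C@@H](OCC)c2ccc(O)c(OC)c2)c(OC)c1` gives 1150 nM and compound 3 `C=CCc1cc(OC)c(O[C@H](C)[C@H](OCC)c2ccc(O)c(OC)c2)c(OC)c1` gives 583 nM; the step of a 2.0-fold lower number from compound 2 to compound 3 (0.30 log units; within the scatter) rests on (the fact that compounds 2 and 3 differ only in the configuration as drawn). Compound 4 `C=CCc1cc(OC)c(OC(C)C(OCCCCCC)c2ccc(O)c(OC)c2)c(OC)c1` carries hydrogen in place of ethyl on a saturated chain carbon, six bonds along the chain from an oxygen on a saturated carbon, a shortening of the chain. Within the data shown here, no measured step bears directly on it: the single measured step, a 2.0-fold lower number from compound 2 to compound 3 (0.30 log units; within the scatter), concerns configuration only, while the ethyl ethers compound 2 and compound 3 stand higher in this assay than compound 1. Shortening toward them is expected to give the step of a 2.3-fold higher number from compound 1 to compound 4 (0.37 log units; beyond the scatter). Compound 4 is estimated at 200 nM, with a range from 70 nM to 600 nM.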

Compound 4, half-maximal effective concentration: 329 nM
Compound 4: the middle estimate sits 1.6-fold (0.22 log units) below what was measured, within the range that was stated.
By their numbers in this assay, from the lowest: compound 1; then compounds 4, 3 and 2 (each within the scatter of the next, the first and the last beyond it).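

In this assay, hydrogen in place of ethyl on a saturated chain carbon, six bonds along the chain from an oxygen on a saturated carbon, gives a 3.8-fold higher number from compound 1 to compound 4 (0.58 log units; beyond the scatter). Among these compounds, this is the first measured step at this ether to change the chain rather than the configuration, and it shows that the chain length registers in the read-out, modestly but beyond the scatter. Nothing at hand gives a cause for this step.

As far as these compounds go, whether a longer chain than that of compound 1 would lower the number further remains open. So does the effect of an amine or a phenyl ring within the chain.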